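From compound 1 to its 4-chlorophenyl relative

The source may report more compounds than this note shows. Statements on the series, on what has been measured and on what is new or still open speak of the compounds shown alone.

Values measured so far in an ADME assay on HaCaT cells (Homo sapiens) for cytotoxicity, read by MTT assay, with a stated time of 48 h (a lower number here means a stronger inhibitor, a higher number a weaker inhibitor), are these
compound 1 `Clc1ccc2[nH]c(-c3cn(-c4ccccc4)nc3-c3ccccc3)nc2c1` gives > 50000 nM as a limit
compound 2 `FC(F)(F)c1ccc2[nH]c(-c3cn(-c4ccccc4)nc3-c3ccccc3)nc2c1` gives 37200 nM as a number
compound 3 `O=C(OCc1ccccc1)c1ccc2[nH]c(-c3cn(-c4ccccc4)nc3-c3ccccc3)nc2c1` gives > 50000 nM as a limit

Compound 1 stands at the limit of > 50000 nM in this assay, at which 2 of the 3 values shown sit, and so is known only by a limit. Compound 4 `Clc1ccc(-c2nn(-c3ccccc3)cc2-c2nc3cc(Cl)ccc3[nH]2)cc1` differs from it by chloro in place of hydrogen on an aromatic carbon and the same difference reads phenyl to 4-chlorophenyl. Within the data shown here, no measured step makes this change. Only steps at another place on the shared core bear on it, and they do so loosely: the series shows an at least 1.3-fold lower number from compound 1 to compound 2 (0.12 log units; that floor lies within the scatter) and then an at least 1.3-fold higher number from compound 2 to compound 3 (0.12 log units; that floor lies within the scatter) as its two steps with a readable floor. The series also holds a step that the two limits leave unreadable from compound 1 to compound 3 as its third step. Among the measured compounds shown here, compound 2 at 37200 nM is the only number to lean on, so no step beyond the scatter is expected in this assay. For compound 4 a further limit is quite possible. The expected size is an at least 1.1-fold lower number from compound 1 to compound 4 (0.04 log units; that floor lies within the scatter) by this estimate. For compound 4 the estimated value is 45000 nM with an expected range from 20000 nM to 90000 nM in all.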

Compound 4, half-maximal inhibitory concentration: > 50000 nM
Compound 4 was reported as a limit (the forecaster's own chance of this, stated with the estimate: 55%); middle value at least 1.1-fold (0.04 log units) away from the limit.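

Among these compounds, compound 4, like compound 1, is known in this assay only by a limit, so no step between the two can be read: the limit of > 50000 nM in this assay, at which 3 of the 4 values shown sit.
The compounds shown leave open whether 4-chlorophenyl in place of phenyl changes the value at all, and in which direction.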